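Cytotoxicity as the chain grows to compound 3

The source may report more compounds than this note shows. Statements on the series, on what has been measured and on what is new or still open speak of the compounds shown alone.

Compound 1 `CCC[C@](C)(CO)Nc1nc(N)nc2cccnc12`, compound 2 `CCCCC[C@](C)(CO)Nc1nc(N)nc2cccnc12` and compound 3 `CCCCCC[C@](C)(CO)Nc1nc(N)nc2cccnc12` share one core and differ only in the length of one chain. In an ADME assay on MT4 cells (Homo sapiens) for cytotoxicity, read by CellTiter-Glo, with a stated time of 5 days (on this read-out lower numbers stand for higher toxicity in this test and higher numbers for lower toxicity in this test), compound 1 gives > 50000 nM, which is a limit of the assay and not a number. For the measured compounds named here, compound 2 gives 17000 nM, the only true number so far. Compound 3 differs from compound 2 by methyl in place of hydrogen on a saturated chain carbon, six bonds along the chain from a nitrogen on an aromatic ring. Going by the values given here, one measured step bears on this change: an at least 2.9-fold lower number from compound 1 to compound 2 (0.46 log units; beyond the scatter), brought by ethyl in place of hydrogen, four bonds along the chain. A modest further fall in this assay is therefore expected, in the same direction, towards higher toxicity. The expected change is a 1.9-fold lower number from compound 2 to compound 3 (0.28 log units; within the scatter). For compound 3 the estimated value is 9000 nM, with an expected range from 4000 nM to 20000 nM.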

Compound 3, half-maximal cytotoxic concentration: 3600 nM
For compound 3 the middle estimate is 2.5-fold (0.40 log units) above the measured one; measured number below the stated range.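

In this assay, for the compounds shown here, methyl in place of hydrogen on a saturated chain carbon, six bonds along the chain from a nitrogen on an aromatic ring, gives a 4.7-fold lower number from compound 2 to compound 3 (0.67 log units; beyond the scatter); this is the only step here between two true numbers, so the fall that comes with the longer chain now has a measured size. Taken together, the whole lengthening of the chain gives an at least 13-fold lower number from compound 1 to compound 3 (1.14 log units; beyond the scatter). The value of compound 1 is a limit and not a number, so this larger step is a bound and not an exact size: the limit of > 50000 nM in this assay, at which 1 of the 3 values shown sits.

From the compounds shown here alone, whether a longer chain would carry the fall further in this assay stays open. Going by these compounds, what an amine or a carboxylic acid on this chain would do also stays open.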